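The source may hold more compounds than are shown below. What is called first, only, known or untested is meant among the compounds shown, and "the series" means these compounds.

In a physicochemical assay for solubility, using the shake flask method, in simulated intestinal fluid, measured as kinetic solubility, with a stated time of 2 h, at 25 degrees C, at pH 6.5 (a lower number here means a less soluble compound, a higher number a more soluble compound), compound 1, `Cc1noc(-c2nc(C)c3c(c2N)C(=O)N(Cc2ccc(OC(F)(F)F)cc2)C3=O)n1`, gives a reading of < 5000 nM, which is a limit of the assay rather than a number. Compound 2, `Cc1noc(-c2nc(C)c3c(c2N)C(=O)N(Cc2cccc(C(F)(F)F)c2)C3=O)n1`, gives in this assay a reading of < 5000 nM, likewise a limit and not a measured number. Compound 2 therefore stands at the limit of < 5000 nM in this assay, at which 2 of the 2 values shown sit; both readings shown in this assay sit there, and no step between measured compounds can be drawn from them.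

Compound 3, `Cc1noc(-c2nc(C)c3c(c2N)C(=O)N(Cc2ccncc2)C3=O)n1`, has not yet been measured in this assay. It differs from compound 2 by pyridin-4-yl in place of 3-(trifluoromethyl)phenyl on a saturated chain carbon bound to an amide-type nitrogen in a ring.

On these data alone, because compound 2 rests at the limit (the limit of < 5000 nM in this assay, at which 2 of the 2 values shown sit), the true starting point of the step is unknown, so its size cannot be read from the numbers. The account nevertheless expects the change to move compound 3 upward in this assay by more than the scatter, while allowing that the reading could again stop at a limit. The estimate for compound 3 in this assay is 20000 nM, with a range from 4000 nM to 100000 nM. This estimate means an expected step of an at least 4.0-fold higher number from compound 2 to compound 3 (0.60 log units; beyond the scatter).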

Compound 3, solubility: 26400 nM
Estimate against measurement, compound 3: 1.3-fold (0.12 log units) below; the range from low to high includes it.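

In this assay, the place on a saturated chain carbon bound to an amide-type nitrogen in a ring now gives a reading that is a number rather than a limit, which neither earlier compound gave. With pyridin-4-yl in place of 3-(trifluoromethyl)phenyl on the shared core, the reading shows an at least 5.2-fold higher number from compound 2 to compound 3 (0.72 log units; beyond the scatter), so a single change at this place goes with a step beyond the scatter. The true size of that step remains unknown and only its lower bound can be read, because its starting point is a limit: the limit of < 5000 nM in this assay, at which 2 of the 3 values shown sit.

The compounds shown leave open whether the ring nitrogen of pyridin-4-yl matters in itself or whether the step follows from the loss of the trifluoromethyl group, a question that an unsubstituted phenyl or a pyridin-3-yl group at this place would help to separate. They also leave open how the reading would respond to an amine, a carboxylic acid or a longer chain at this place.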